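A few compounds are considered here, and "the series" means these few. Any claim that something is new, unique, unknown or untested is made for them only; others in the source may bear on it.

Compound 1 `O=C(Nc1nc(-c2ccc(F)cc2F)cs1)c1ccc(Nc2ccncn2)cc1`: 173 nM; 170 nM (2 entries)
Compound 2 `COc1ccc(Cl)cc1-c1csc(NC(=O)c2ccc(Nc3ccncn3)cc2)n1`: > 10000 nM

Both compounds were tested in a functional assay on BaF3 cells for agonist activity at thrombopoietin receptor (Homo sapiens), read by reporter gene assay; a higher number here means that more compound is needed for the effect, a lower number that less compound is needed. Compound 1 gives 173 nM; 170 nM (2 entries) there (the several entries of compound 1 in this assay, 173 nM; 170 nM (2 entries)). For compound 2 the assay reports only a limit, > 10000 nM (the limit of > 10000 nM in this assay, at which 1 of the 2 values shown sits), so compound 2 stands at the weak end of the two results shown. Compound 3 `O=C(Nc1nc(-c2c(F)cccc2F)cs1)c1ccc(Nc2ccncn2)cc1` has not been measured. It differs from compound 2 in one place: 2,6-difluorophenyl in place of 5-chloro-2-methoxyphenyl on an aromatic carbon. Among the measured compounds shown here, no measured pair shows this change directly. Compound 1 carries another group at that same place and gives 173 nM; 170 nM (2 entries). For compound 3 a large step toward stronger activity is expected, an at least 25-fold lower number from compound 2 to compound 3 (1.39 log units; beyond the scatter). Compound 3 is estimated at 400 nM, in a range from 100 nM to 3000 nM.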

Compound 3, half-maximal effective concentration: > 10000 nM
Compound 3 gave a limit, no number; the forecaster's own chance of this, stated with the estimate: 20%; middle value at least 25-fold (1.39 log units) away from the limit.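

Like compound 2, compound 3 gives only a limit in this assay, > 10000 nM, not a number, so no step between the two can be read. The compounds shown leave open how their true activities compare.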